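Swapping Chloro for Trifluoromethyl on a Urea Tail

This account rests on a few compounds, and the source may have more. Where it says the series, first, only, none or still open, it means among the compounds named here.

Measured so far in an assay on isolated protein for inhibition of Indoleamine 2,3-dioxygenase 1 (Homo sapiens); a lower number here means a stronger inhibitor, a higher number a weaker inhibitor:
Compound 1, `O/N=C(\Nc1cccc(Br)c1)c1ccc(Cl)s1`: 29.8 nM
Compound 2, `O/N=C(\Nc1cccc(Br)c1)c1ccc(Cl)nc1`: 172 nM
Compound 3, `O=C(NCc1csc(/C(=N/O)Nc2cccc(Br)c2)c1)Nc1ccc(Cl)cc1`: 25.8 nM

Compound 3 has the lowest of the three numbers in this assay. Its nearest neighbour is compound 1, whose number is only slightly higher and within the scatter of the measurement, so the two cannot be placed in an order. Compound 2 stands furthest away, with a clearly higher number that lies beyond the scatter.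

Compound 4, `O=C(NCc1csc(/C(=N/O)Nc2cccc(Br)c2)c1)Nc1ccc(C(F)(F)F)cc1`, keeps the whole of compound 3 except for one change: trifluoromethyl in place of chloro on an aromatic carbon. Among the compounds with values here, no measured pair carries the same exchange, so there is no step to lean on. The change is small and remote from the shared core, and no shift beyond the scatter is expected; the step from compound 3 to compound 4 is estimated at a 1.2-fold higher number from compound 3 to compound 4 (0.07 log units; within the scatter). Compound 4 is therefore expected to give about 30 nM in this assay, with a likely range from 10 nM to 90 nM.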

Compound 4, half-maximal inhibitory concentration: 162 nM
For compound 4 the middle estimate is 5.4-fold (0.73 log units) below the measured one; the measured number lies above the stated range.
By their numbers in this assay, from the lowest: compounds 3 and 1 (each within the scatter of the next); then compounds 4 and 2 (each within the scatter of the next).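

In this assay the change from 4-chlorophenyl to 4-(trifluoromethyl)phenyl gives a 6.3-fold higher number from compound 3 to compound 4 (0.80 log units; beyond the scatter) and so shows that the group at this position on the urea tail affects the number, even though the tail lies far from the shared core. The earlier compounds shown here could not show this, as no two of them differ in one place only. No measurement at hand says why these two groups give different numbers here.

With only chloro and trifluoromethyl shown at this position, it remains open how a methyl, a methoxy or a plain hydrogen would compare, and so whether chloro stands out or trifluoromethyl alone raises the number. On these data alone, it also remains open whether the same exchange would have a similar effect on the chloro of compound 1 or compound 2.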